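Methylpyridinyl Ether Replacing Cyanopyridinyl Ether in Cytotoxicity

The source may report more compounds than this note shows. Statements on the series, on what has been measured and on what is new or still open speak of the compounds shown alone.

Compound 1 `CC(CCNC(=O)c1c(Cl)cncc1Cl)N1CCC(C(Oc2cccc(C#N)n2)c2ccc(C(F)(F)F)cc2)CC1` is the reference point of this account. In an ADME assay on PBMC cells (Homo sapiens) for cytotoxicity (a higher number here means that more compound is tolerated, a lower number that less compound is tolerated), compound 1 gives 15700 nM, the lowest of the three numbers recorded so far. Compound 2 `CC(CCNC(=O)c1c(Cl)cncc1Cl)N1CCC(C(Oc2ccncc2)c2ccc(Br)cc2)CC1` gives 31200 nM, a gap that remains within the scatter of the measurement, while compound 3 `CCO/N=C(/c1ccc(Br)cc1)C1CCN(C(C)(C)CCNC(=O)c2c(Cl)cncc2Cl)CC1` gives 34000 nM, a gap just beyond it. No pair among these three differs in only one place, so none of them provides a step to lean on.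

Compound 4 `Cc1cccnc1OC(c1ccc(C(F)(F)F)cc1)C1CCN(C(C)CCNC(=O)c2c(Cl)cncc2Cl)CC1` differs from compound 1 in a single position: 3-methylpyridin-2-yl in place of 6-cyanopyridin-2-yl on an oxygen on a saturated carbon. Both groups are six-membered aromatic rings with one hetero atom on the same oxygen; the outgoing group carries a nitrile and the incoming one a methyl. For the measured compounds named here, with no measured step of this kind available, the expectation is that compound 4 stays close to compound 1, with any shift a 1.3-fold higher number from compound 1 to compound 4 (0.11 log units; within the scatter) not beyond the scatter. Compound 4 is therefore estimated at 20000 nM, within a range of 8000 nM to 50000 nM.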

Compound 4, half-maximal cytotoxic concentration: 33000 nM
Compound 4: the middle estimate sits 1.7-fold (0.22 log units) below what was measured; low and high end bracket the measured number.
By their numbers in this assay, from the lowest: compounds 1, 2, 4 and 3 (each within the scatter of the next, the first and the last beyond it).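

For the compounds shown here, exchanging 6-cyanopyridin-2-yl for 3-methylpyridin-2-yl on this oxygen gives the first single-change comparison in this assay and shows a 2.1-fold higher number from compound 1 to compound 4 (0.32 log units; beyond the scatter). The step is modest, but it shows that the group on this oxygen can move the tolerated concentration while the rest of compound 1 stays fixed, even when the incoming group keeps the same kind of aromatic ring. Nothing available explains why the number moves with this exchange.

The step changes both the substituent on the ring and where it sits, so the effect of replacing the nitrile with a methyl cannot be separated from the effect of its placement. Going by these compounds, how an amine or a carboxylic acid on the pyridin-2-yl ring would read in this measurement also remains open.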